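A few compounds are considered here, and "the series" means these few. Any claim that something is new, unique, unknown or untested is made for them only; others in the source may bear on it.

Measured compounds:
Compound 1, `COc1ccc([C@@H]2CC(=O)c3c(O)cc(OCc4cn(Cc5ccc(F)cc5)nn4)cc3O2)cc1O` — 15100 nM
Compound 2, `COc1ccc([C@@H]2C/C(=N\O)c3c(O)cc(OCc4cn(Cc5ccccc5C)nn4)cc3O2)cc1O` — 18000 nM
Compound 3, `CCCn1cc(COc2cc(O)c3c(c2)O[C@H](c2ccc(OC)c(O)c2)C/C3=N\O)nn1` — 2340 nM

In a functional assay on RAW264.7 cells (Mus musculus) for inhibition, read by Griess assay, with stated times of 2 h and 24 h (a higher number here means a weaker inhibitor, a lower number a stronger inhibitor), compound 1 stands second highest of the three numbers; its value and that of compound 2 lie within the scatter of each other, while compound 3 gives a clearly lower number. Compound 4, `COc1ccc([C@@H]2CC(=O)c3c(O)cc(OCc4cn(Cc5cccc(C)c5)nn4)cc3O2)cc1O`, differs from compound 1 in one place: 3-methylphenyl in place of 4-fluorophenyl on a saturated chain carbon bound to an aromatic nitrogen. Among the compounds with values here, no measured step exchanges one aromatic ring for another on that carbon. Within the data shown here, the only measured step, a 7.7-fold lower number from compound 2 to compound 3 (0.89 log units; beyond the scatter), replaces an aromatic ring with a short chain, a different kind of change, and so bears only loosely here. Among the measured compounds shown here, with no direct precedent, compound 4 is expected to remain close to compound 1, with a step of a 1.1-fold lower number from compound 1 to compound 4 (0.03 log units; within the scatter) in this assay. Compound 4 is therefore estimated at 14000 nM, within 6000 nM to 35000 nM.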

Compound 4, half-maximal inhibitory concentration: 17400 nM
Compound 4: middle estimate off by 1.2-fold (0.09 log units), on the low side; the measured number falls inside the stated range.
By their numbers in this assay, from the lowest: compound 3; then compounds 1, 4 and 2 (each within the scatter of the next).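

In this assay, 3-methylphenyl in place of 4-fluorophenyl on a saturated chain carbon bound to an aromatic nitrogen gives a 1.2-fold higher number from compound 1 to compound 4 (0.06 log units; within the scatter). Among the compounds shown, this is the only exchange of one aromatic ring for another at this position, and the two rings cannot be told apart in this measurement. No measured evidence accounts for this result.

As far as these compounds go, the short-chain change, a 7.7-fold lower number from compound 2 to compound 3 (0.89 log units; beyond the scatter), comes from a different pair, so ethyl or a longer chain such as hexyl on the core of compound 1 remains open. So does a benzyl ring carrying an amine or a carboxylic acid.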